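Swapping a methoxy for a methylsulfonyl: solubility outlook

The source may hold more compounds than are shown below. What is called first, only, known or untested is meant among the compounds shown, and "the series" means these compounds.

Of the compounds shown here, two have been measured in a physicochemical assay for solubility, using the shake flask method, in simulated intestinal fluid, measured as kinetic solubility, with a stated time of 2 h, at 25 degrees C, at pH 6.5; on this read-out higher numbers stand for higher solubility and lower numbers for lower solubility. Compound 1, `Cc1nc(C(N)=O)c(N)c2c1C(=O)N(Cc1ccccc1)C2=O`, returns only a limit in this assay, < 5000 nM. Compound 2, `COc1ccc(CN2C(=O)c3c(C)nc(-c4nc(C)no4)c(N)c3C2=O)cc1`, likewise returns only a limit in this assay, < 5000 nM. So compound 2 stands at the limit, not at a number, and the limit of < 5000 nM in this assay, at which 2 of the 2 values shown sit, holds for every value shown so far; no step between two measured values is available to guide expectations.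

Compound 3, `Cc1noc(-c2nc(C)c3c(c2N)C(=O)N(Cc2ccc(S(C)(=O)=O)cc2)C3=O)n1`, is not yet measured. Its structure differs from compound 2 in one place: methylsulfonyl in place of methoxy on an aromatic carbon. Since the shown data give no measured step in this assay, the size and direction of the change are uncertain; a modest rise in solubility is expected, likely within or just beyond the scatter. Compound 3 is therefore estimated at 5000 nM, with a plausible range from 1500 nM to 20000 nM, which corresponds to the expected step of a number no lower from compound 2 to compound 3 (the limit leaves the size open).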

Compound 3, solubility: < 5000 nM
Compound 3: a limit, no number; the forecaster's own chance of this, stated with the estimate: 50%; the middle value sits exactly at the limit.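

Compound 2 and compound 3 each return only a limit in this assay, so no step can be read between them, and the same holds for every value shown: the limit of < 5000 nM in this assay, at which 3 of the 3 values shown sit.

The compounds shown leave open how soluble any of them actually is, and whether methylsulfonyl in place of methoxy changes that at all.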